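The source may hold more compounds than are shown below. What is called first, only, known or untested is meant among the compounds shown, and "the series" means these compounds.

Measured so far:
compound 1 `CCC(=O)C(=O)[C@H](CC)NC(=O)[C@H](CC(C)C)NC(=O)[C@H](CC(C)C)NC(=O)OCc1ccccc1` gives 2600 nM
compound 2 `CCCCNC(=O)C(=O)C(CC)NC(=O)C(CC(C)C)NC(=O)OCc1ccccc1` gives 50 nM

In an assay on isolated protein (Oryctolagus cuniculus) for inhibition of Calpain-2 catalytic subunit (Homo sapiens), at pH 8.0 (on this read-out lower numbers stand for stronger inhibition and higher numbers for weaker inhibition), compound 2 stands at the lower of the two numbers, and compound 1 sits beyond the scatter above it. Compound 3 `CCC(NC(=O)C(CC(C)C)NC(=O)OCc1ccccc1)C(=O)C(=O)O` has not been measured. Relative to compound 2 the change is hydroxy in place of butylamino on a carbonyl carbon. Among the compounds with values here, no pair of measured compounds covers this change, so its size cannot be read from the series; a loss beyond the scatter is expected, the step being estimated at a 12-fold higher number from compound 2 to compound 3 (1.08 log units; beyond the scatter). Compound 3 is expected to give an inhibition constant near 600 nM, between 120 nM and 3000 nM.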

Compound 3, inhibition constant: 22 nM
Compound 3: the middle estimate sits 27-fold (1.44 log units) above what was measured; measured number below the stated range.
By their numbers in this assay, from the lowest: compound 3; then compound 2; then compound 1.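

Hydroxy in place of butylamino on a carbonyl carbon gives a 2.3-fold lower number from compound 2 to compound 3 (0.36 log units; beyond the scatter) in this assay as a modest gain. Butylamino is therefore not needed at this position to hold inhibition at this level, and the smaller hydroxy is at least as well accepted here. Nothing at hand explains the direction of this step.

Still open, as far as these compounds go, is how groups of intermediate size on this carbonyl carbon, such as methylamino or an unsubstituted amine, would compare. A methyl ester or a longer chain such as hexylamino is equally unresolved.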